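The compounds below may be only part of what the source reports. "The series", "measured", "known", "first", "only" and "open" are said of these compounds alone.

The series is anchored by compound 1 `CCCCCCCCn1cc(COC[C@@H]2OC[C@H](N)[C@@H]2O)nn1`, which gives 44300 nM in a functional assay on EC9706 cells (Homo sapiens) for antiproliferative activity, read by MTT assay, with a stated time of 48 h; on this read-out higher numbers stand for weaker inhibition and lower numbers for stronger inhibition. Compound 2 `CCCCCCCn1cc(COC[C@@H]2OC[C@H](N)[C@H]2O)nn1` gives > 128000 nM in this assay, and this is a limit of the assay, not a number. Compound 3 `CCCCCCCCn1cc(COC[C@@H]2OC[C@H](N)[C@H]2O)nn1` differs from compound 2 by methyl in place of hydrogen on a saturated chain carbon, seven bonds along the chain from an aromatic nitrogen. Going by the values given here, no measured step shows this change, so a modest shift towards stronger inhibition in this assay is expected, with compound 1 at 44300 nM as the nearest guide. The expected step is an at least 1.9-fold lower number from compound 2 to compound 3 (0.29 log units; that floor lies within the scatter). Compound 3 is estimated at 65000 nM, with an expected range of 25000 nM to 160000 nM.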

Compound 3, half-maximal inhibitory concentration: > 128000 nM
Compound 3: no number, only a limit; the forecaster's own chance of this, stated with the estimate: 35%; at least 1.9-fold (0.29 log units) between middle value and limit.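

The step from hydrogen to methyl on the chain cannot be read, since both compounds at this position stand only as limits of the assay: the limit of > 128000 nM in this assay, at which 2 of the 3 values shown sit. Going by these compounds alone, the one readable comparison is an at least 2.8-fold higher number from compound 1 to compound 3 (0.46 log units; beyond the scatter), and it shows that the same chain can give a measurable value in one configuration and only a limit in another. The stereocentre at the saturated ring carbon, drawn S in compound 1 and R in compound 3, is the only possible source of that step: the fact that compounds 1 and 3 differ only in the configuration as drawn.

From the compounds shown here alone, how the shorter chain of compound 2 reads on the configuration of compound 1 stays open. So does whether a longer chain on that configuration gives stronger inhibition in this assay.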